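Moving the Acid onto a Benzene Ring

A few compounds are considered here, and "the series" means these few. Any claim that something is new, unique, unknown or untested is made for them only; others in the source may bear on it.

Measured so far:
compound 1, `CCCCn1nc(-c2cccnc2)c2ccccc2c1=O`, 91%;
compound 2, `O=C(O)Cn1nc(-c2cccnc2)c2ccccc2c1=O`, 13%.

In an assay on isolated protein (Oryctolagus cuniculus) with Thromboxane-A synthase (Homo sapiens) as the target, tested at 1 uM (on this read-out lower numbers stand for less inhibition and higher numbers for more inhibition at the one concentration tested (going by the name of the read-out)), compound 1 gives 91%, while compound 2 gives 13%. Among the compounds with values here, compound 2 thus stands lowest of the two numbers, and its only neighbour is compound 1, which lies far above it: the single measured step, a number 78 percentage points lower from compound 1 to compound 2 (beyond the scatter), shows how strongly a carboxy group in place of propyl on the saturated chain carbon bound to the aromatic nitrogen lowers inhibition.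

Compound 3, `O=C(O)c1ccc(Cn2nc(-c3cccnc3)c3ccccc3c2=O)cc1`, has not yet been measured. It keeps the acid but carries it on a benzene ring: 4-carboxyphenyl in place of carboxy on a saturated chain carbon bound to an aromatic nitrogen. Within the data shown here, no measured pair covers this exact change, so the step from compound 1 to compound 2 is the only guide. That step is large and points downward when a bare carboxy replaces a propyl chain; compound 3 instead adds a ring between the chain carbon and the acid, which brings it closer in size to compound 1 while retaining the acid of compound 2. An upward step is therefore expected, estimated at a number 42 percentage points higher from compound 2 to compound 3 (beyond the scatter) in this assay, though its size is uncertain. Compound 3 is expected to give about 55%, within a range from 20% to 88%.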

Compound 3, a percentage reported as inhibition, at one concentration (the size of the read-out at that concentration, not a potency): 64%
The estimate for compound 3 lay 9 percentage points below the measured number; measured number inside the range.
By their numbers in this assay, from the lowest: compound 2; then compound 3; then compound 1.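

In this assay, the presence of the acid does not settle the result at this position on its own. Carrying it as 4-carboxyphenyl rather than as a bare carboxy gives a number 51 percentage points higher from compound 2 to compound 3 (beyond the scatter), so on a saturated chain carbon bound to an aromatic nitrogen, the form in which the acid arrives matters a great deal. The acid-bearing ring does not close the whole gap, however: replacing propyl with 4-carboxyphenyl still leaves a number 27 percentage points lower from compound 1 to compound 3 (beyond the scatter), a modest step compared with the large fall seen for the bare carboxy, and nothing measured here explains either step.

Going by these compounds, it remains open whether the recovery belongs to the benzene ring itself or to the ring and acid together, and a plain phenyl group with no acid at this place would help separate those two readings. A longer saturated chain ending in a carboxylic acid would show whether added chain length alone can do what the ring does, while a methyl ester on the ring would test whether the free acid is needed at all.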